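Ether to Amide on the Saturated Ring Carbon

This account rests on a few compounds, and the source may have more. Where it says the series, first, only, none or still open, it means among the compounds named here.

Compound 1 `NS(=O)(=O)OC[C@@H]1C[C@@H](n2nnc3c(N[C@H]4CCc5ccccc54)ncnc32)C[C@@H]1O` gives 0.21 nM in an assay on a protein complex for inhibition of NEDD8 activating enzyme (Homo sapiens), read by HTRF, with a stated time of 2 h, in the presence of a further agent that is not named here; a lower number here means a stronger inhibitor, a higher number a weaker inhibitor. Among the measured compounds shown here, compound 2 `COCCO[C@H]1Cc2ccccc2[C@H]1Nc1ncnc2c1nnn2[C@@H]1C[C@@H](COS(N)(=O)=O)[C@@H](O)C1` gives 3.56 nM in this assay, the higher of the two numbers; the only measured step, a 17-fold higher number from compound 1 to compound 2 (1.23 log units; beyond the scatter), shows how much a group in place of hydrogen on that carbon raised the number. Compound 3 `COCC(=O)N[C@H]1Cc2ccccc2[C@H]1Nc1ncnc2c1nnn2[C@@H]1C[C@@H](COS(N)(=O)=O)[C@@H](O)C1` differs from compound 2 by ((methoxymethyl)carbonyl)amino in place of 2-methoxyethoxy on a saturated ring carbon. For the measured compounds named here, no measured step covers an exchange of one such group for another, so compound 3 is expected to stay near compound 2, with a 1.0-fold lower number from compound 2 to compound 3 (0.01 log units; within the scatter) lying within the scatter. Compound 3 is therefore estimated at 3.5 nM, between 1 nM and 12 nM.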

Compound 3, half-maximal inhibitory concentration: 170 nM
The estimate for compound 3 lay 49-fold (1.69 log units) below the measured number, outside the stated range (above it).
By their numbers in this assay, from the lowest: compound 1; then compound 2; then compound 3.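

In this assay, this saturated ring carbon clearly distinguishes between two chains of similar length: the change gives a 48-fold higher number from compound 2 to compound 3 (1.68 log units; beyond the scatter), and the entering group carries a hydrogen-bond donor that 2-methoxyethoxy lacks. Measured against hydrogen, the amide shows an 810-fold higher number from compound 1 to compound 3 (2.91 log units; beyond the scatter), so the number at this carbon depends on the group placed there and not merely on the presence of a substituent. Nothing available explains this difference.

The compounds shown leave open whether the amide hydrogen or the carbonyl goes with the higher number. They also leave open how a free amine, a hydroxyl or a shorter methoxy group would behave at this carbon.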